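The source may hold more compounds than are shown below. What is called first, only, known or untested is meant among the compounds shown, and "the series" means these compounds.

Measured so far in an ADME assay on Vero cells (Chlorocebus sabaeus) for cytotoxicity, read by resazurin assay, with a stated time of 72 h; on this read-out lower numbers stand for stronger inhibition and higher numbers for weaker inhibition:
- compound 1 `COc1ccc(C(=O)CCN2CCN(c3ccc(C(F)(F)F)cc3)CC2)cc1`: 135000 nM
- compound 2 `COc1ccc(C(=O)CCN2CCN(c3ccc(Cl)cc3)CC2)cc1`: 300000 nM

Compound 2 has the higher of these two numbers, and so the weaker effect on the cells. Within the data shown here, its only neighbour on the scale is compound 1, and the gap between them is a 2.2-fold higher number from compound 1 to compound 2 (0.35 log units; beyond the scatter). That modest step came from putting chloro in place of trifluoromethyl on an aromatic carbon.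

The next comparison is with compound 3 `COc1ccc(C(=O)CCN2CCN(c3ccc([N+](=O)[O-])cc3)CC2)cc1`, which has nitro in place of chloro on an aromatic carbon. The group changes on a six-membered aromatic ring of carbon only, para to a large group.

Among the measured compounds shown here, the one measured step, a 2.2-fold higher number from compound 1 to compound 2 (0.35 log units; beyond the scatter), is the only guide, and it involves a different pair of groups. The data do not show how nitro compares with either of them. A modest change at most therefore seems likely, perhaps toward a somewhat lower number, and it may not clear the usual scatter. The expected change is a 1.5-fold lower number from compound 2 to compound 3 (0.18 log units; within the scatter). The estimated value for compound 3 is 200000 nM, with an expected range of 80000 nM to 400000 nM.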

Compound 3, half-maximal inhibitory concentration: 587000 nM
Compound 3: middle estimate off by 2.9-fold (0.47 log units), on the low side; the whole stated range lies below it.
By their numbers in this assay, from the lowest: compound 1; then compounds 2 and 3 (each within the scatter of the next).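

In this assay, putting nitro in place of chloro on this aromatic carbon gives a 2.0-fold higher number from compound 2 to compound 3 (0.29 log units; within the scatter) and so does not clearly separate the two groups, even though nitro brings more heavy atoms and two hydrogen-bond acceptors that chloro lacks. Measured against trifluoromethyl at the same place, the nitro group gives a 4.3-fold higher number from compound 1 to compound 3 (0.64 log units; beyond the scatter) and, with the earlier step, this leaves compound 1 alone at the low end of the three numbers, while compound 2 and compound 3 stay together at the high end. Nothing among the available data gives a reason for this grouping.

An amine, a carboxylic acid or a plain hydrogen on this same aromatic carbon could land with compound 1, with the other two compounds, or somewhere else entirely, and the compounds shown give no way to tell which. Going by these compounds, all three also share one core, so it remains open whether trifluoromethyl would still stand apart from chloro and nitro if the methoxy group or the chain carrying the carbonyl were different.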